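Ester ring size and aryl swap in a small series

A few compounds are considered here, and "the series" means these few. Any claim that something is new, unique, unknown or untested is made for them only; others in the source may bear on it.

Of the compounds shown here, three have been measured in an assay on membranes from HeLa cells for displacement of a labelled ligand from adenosine receptor A3 (Homo sapiens), read by scintillation counting, with a stated time of 180 min, tested at 1 uM (a higher number here means more inhibition at the concentration tested (going by the name of the read-out), a lower number less inhibition), and a fourth remains to be run. Compound 1 `CC1=C(C(=O)OC2CCCC2)C(c2ccoc2)NC(=O)N1` gives 1% in this assay. Compound 2 `CC1=C(C(=O)OC2CCCCC2)C(c2ccoc2)NC(=O)N1` gives 1% in this assay. Compound 3 `CC1=C(C(=O)OC2CCCC2)C(c2cccs2)NC(=O)N1` gives 1% in this assay. All three sit at the same level at the digits read, and the two steps among them, no change at the digits printed from compound 1 to compound 2 (within the scatter) and no change at the digits printed from compound 1 to compound 3 (within the scatter), lie within the scatter of the method.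

The change from compound 1 to compound 2 is cyclohexyl in place of cyclopentyl on an oxygen next to a carbonyl group. Compound 3 differs from compound 1 by thiophen-2-yl in place of furan-3-yl on a saturated ring carbon, and the unmeasured compound 4 `CC1=C(C(=O)OC2CCCCC2)C(c2cccs2)NC(=O)N1` is obtained from compound 3 by cyclohexyl in place of cyclopentyl on an oxygen next to a carbonyl group. The place of this change is the same, word for word, as the place of the change from compound 1 to compound 2, so it is the same change made on a core that differs only by the aryl swap just described. Going by the values given here, its only measured instance, no change at the digits printed from compound 1 to compound 2 (within the scatter), left the read-out unchanged at the digits read.

Among the compounds with values here, no compound in this set shows any inhibition beyond the floor of the read-out, so there is nothing to suggest the ester ring size has an effect here. The step from compound 3 to compound 4 is therefore expected to be no change at the digits printed from compound 3 to compound 4 (within the scatter), because compound 1 to compound 2 gave no change at the digits printed from compound 1 to compound 2 (within the scatter). Compound 4 is estimated at 1%, between -6% and 8%, in this assay.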

Compound 4, a percentage reported as inhibition, at one concentration (the size of the read-out at that concentration, not a potency): 1%
Compound 4: the middle estimate sits on the measured number at the digits printed; low and high end bracket the measured number.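

On the core of compound 3, cyclohexyl in place of cyclopentyl on an oxygen next to a carbonyl group gives no change at the digits printed from compound 3 to compound 4 (within the scatter) in this assay, which agrees with the same change on the core of compound 1: the same change on two cores in this assay, no change at the digits printed (within the scatter) from compound 1 to compound 2 and no change at the digits printed (within the scatter) from compound 3 to compound 4, 0 percentage points apart, within the scatter of two such steps. Thiophen-2-yl in place of furan-3-yl on a saturated ring carbon gives no change at the digits printed from compound 2 to compound 4 (within the scatter), and this swap also reads alike on its two cores: the same change on two cores in this assay, no change at the digits printed (within the scatter) from compound 1 to compound 3 and no change at the digits printed (within the scatter) from compound 2 to compound 4, 0 percentage points apart, within the scatter of two such steps. Going by these compounds alone, all four compounds nevertheless sit at one level, so the agreement shows only that neither change moves the read-out on these cores; it does not show that an effect of either change would carry from one core to another, since no step of measurable size is available to compare.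

The compounds shown leave open whether any other group on the ester oxygen, such as a longer chain or a chain ending in an amine or a carboxylic acid, or phenyl in place of the furan-3-yl and thiophen-2-yl groups, would lift the read-out off this level. With a reading at only one concentration, they also leave open whether any of the four has activity at this receptor at a higher concentration.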